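Series notes: ether chain replacing tert-butyl on compound 2

A few compounds are considered here, and "the series" means these few. Any claim that something is new, unique, unknown or untested is made for them only; others in the source may bear on it.

Measured compounds in an assay on isolated protein for agonist activity at prostaglandin E2 receptor EP4 subtype (Homo sapiens); on this read-out lower numbers stand for an effect already at smaller amounts and higher numbers for an effect only at larger amounts of compound:
compound 1 `CCCCC(C)(C)[C@H](O)/C=C/[C@H]1CCC(=O)N1CCSc1nc(C(=O)O)cs1`, 4.2 nM
compound 2 `CC(C)(C)CCC1([C@H](O)/C=C/[C@H]2COC(=O)N2CCSc2nc(C(=O)O)cs2)CCC1`, 4710 nM
compound 3 `CCCC[C@H](C)C[C@H](O)/C=C/[C@H]1CCC(=O)N1CCSc1nc(C(=O)O)cs1`, 3 nM

Compound 2 has the highest number of the three in this assay; its distance to compound 1 and to compound 3 is beyond the scatter in each case, so compound 2 is the least potent of the measured set. Compounds 1 and 3 lie within the scatter of each other, a 1.4-fold lower number from compound 1 to compound 3 (0.15 log units; within the scatter).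

Compound 4 `COCCCC1([C@H](O)/C=C/[C@H]2COC(=O)N2CCSc2nc(C(=O)O)cs2)CCC1` is not yet measured. Its difference from compound 2 is methoxymethyl in place of tert-butyl on a saturated chain carbon, two bonds along the chain from a saturated ring carbon.

Going by the values given here, no measured step bears on this change. Among the compounds with values here, the only step in hand, from compound 1 to compound 3, alters a different place and is within the scatter, and neither compound 1 nor compound 3 shares the cyclobutyl-bearing core of compound 2. The change in compound 4 exchanges a hydrocarbon end for an ether end at the same place; nothing in the data speaks for a gain or a loss. Compound 4 is therefore expected to stay close to compound 2, with a step of a 1.2-fold lower number from compound 2 to compound 4 (0.07 log units; within the scatter), given wide uncertainty.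

Compound 4 is estimated at 4000 nM in this assay, expected between 1200 nM and 13000 nM.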

Compound 4, half-maximal effective concentration: 705 nM
Compound 4: middle estimate off by 5.7-fold (0.75 log units), on the high side; measured number below the stated range.
By their numbers in this assay, from the lowest: compounds 3 and 1 (each within the scatter of the next); then compound 4; then compound 2.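

At this place on the chain, on a saturated chain carbon two bonds along from a saturated ring carbon, the read-out in this assay responds to what stands at the chain end: the step is a 6.7-fold lower number from compound 2 to compound 4 (0.82 log units; beyond the scatter). Going by these compounds alone, the one earlier step, at a different place and on a different core, was a 1.4-fold lower number from compound 1 to compound 3 (0.15 log units; within the scatter), so it gave no sign of how this position would behave. On the shared core of compound 2 and compound 4, a tert-butyl end is therefore not needed for the lower of the two numbers, and an ether end in the form of 3-methoxypropyl in place of 3,3-dimethylbutyl is accepted at this place. Nothing in hand gives a reason for this step.

The step joins two changes in one, the removal of the branched end and the entry of an ether oxygen, and the compounds shown leave open which of the two accounts for the difference; a plain pentyl chain at the same place would separate them. Also open, from the compounds shown here alone, is how a 3-hydroxypropyl or a 3-aminopropyl chain would read here, and whether the exchange gives a similar step on the core of compound 1.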